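Demethylation of Benzofuran Amidines and Imidazolines in a Cytotoxicity Assay

The source may report more compounds than this note shows. Statements on the series, on what has been measured and on what is new or still open speak of the compounds shown alone.

Measured compounds:
compound 1, `COc1cc(C(=N)N)ccc1-c1cc2ccc(C(=N)N)cc2o1`: 108000 nM
compound 2, `COc1cc(C2=NCCN2)ccc1-c1cc2ccc(C3=NCCN3)cc2o1`: 4400 nM
compound 3, `N=C(N)c1ccc(-c2cc3ccc(C(=N)N)cc3o2)c(O)c1`: > 221000 nM, a limit

In an ADME assay on L6 cells (Rattus norvegicus) for cytotoxicity (on this read-out lower numbers stand for stronger inhibition and higher numbers for weaker inhibition), compound 1 gives 108000 nM. The core of compound 2 differs from that of compound 1 in a way that is not broken down here. In this assay compound 2 gives 4400 nM, the lowest of the two numbers. For compound 3 only a limit is recorded, > 221000 nM, the value sitting at the limit of > 221000 nM in this assay, at which 1 of the 3 values shown sits. The change from compound 1 to compound 3, (hydrogen in place of methyl on an oxygen on an aromatic ring), brought an at least 2.0-fold higher number from compound 1 to compound 3 (0.31 log units; beyond the scatter).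

Compound 4, `Oc1cc(C2=NCCN2)ccc1-c1cc2ccc(C3=NCCN3)cc2o1`, has not yet been measured in this assay. It differs from compound 2 by the same change, (hydrogen in place of methyl on an oxygen on an aromatic ring). The step from compound 2 to compound 4 is expected to resemble the measured one, resting on an at least 2.0-fold higher number from compound 1 to compound 3 (0.31 log units; beyond the scatter), giving an estimated 2.5-fold higher number from compound 2 to compound 4 (0.40 log units; beyond the scatter). Compound 4 is therefore expected to give about 11000 nM. The estimate for compound 4 is expected to fall between 4000 nM and 35000 nM.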

Compound 4, half-maximal inhibitory concentration: > 193000 nM
Compound 4 was reported as a limit; the forecaster's own chance of this, stated with the estimate: 5%; middle value at least 17-fold (1.24 log units) away from the limit.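

In this assay, the change from methoxy to hydroxy on the core of compound 2 gave an at least 43-fold higher number from compound 2 to compound 4 (1.64 log units; beyond the scatter) and so moved the number in the same direction as on the core of compound 1. Compound 4 is recorded at > 193000 nM which is a limit, and the two steps compare as follows: the same change on two cores in this assay, an at least 2.0-fold higher number (0.31 log units; beyond the scatter) from compound 1 to compound 3 and an at least 43-fold higher number (1.64 log units; beyond the scatter) from compound 2 to compound 4; the limit leaves it open whether they differ. The direction of the change therefore carried from one core to the other, but the data show neither that its size carried over nor that its size differs between the cores.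

The compounds shown leave open how either core would respond to an ethoxy group or an amine on the aromatic ring in place of methoxy or hydroxy.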